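Compound 2 to compound 4: 3-fluorobenzyl in the series

The source may report more compounds than this note shows. Statements on the series, on what has been measured and on what is new or still open speak of the compounds shown alone.

In an ADME assay on HEK-293T cells (Homo sapiens) for inhibition, read by CCK-8 assay, with a stated time of 48 h, tested at 20 uM (a lower number here means less inhibition of growth, a higher number more inhibition of growth at the concentration tested), compound 1 (`N#C/C(=C\c1ccccc1OS(=O)(=O)c1ccc([N+](=O)[O-])cc1)C(=O)Nc1nnc(Cc2ccccc2)s1`) gives "not toxic" (no number reported), with no number reported. Compound 2 (`N#C/C(=C\c1ccccc1OS(=O)(=O)c1ccc([N+](=O)[O-])cc1)C(=O)Nc1nnc(Cc2ccc(F)cc2)s1`) gives 8%. Compound 3 (`N#C/C(=C\c1ccccc1OS(=O)(=O)c1ccccc1[N+](=O)[O-])C(=O)Nc1nnc(Cc2ccc(F)cc2)s1`) gives 6%, which lies within the scatter of compound 2, so the two numbers cannot be ranked.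

Compound 4 (`N#C/C(=C\c1ccccc1OS(=O)(=O)c1ccc([N+](=O)[O-])cc1)C(=O)Nc1nnc(Cc2cccc(F)c2)s1`) carries 3-fluorophenyl in place of 4-fluorophenyl on a saturated chain carbon bound to an aromatic carbon. The two structures have the same atoms, joined differently.

Going by the values given here, the only measured step is a number 2 percentage points lower from compound 2 to compound 3 (within the scatter). It swaps 2-nitrophenyl in place of 4-nitrophenyl on a sulfonyl sulfur, so it is a change at another place and bears only indirectly. Among the compounds with values here, no measured step touches the fluorophenyl group, and the evidence is thin.

On that basis, no step beyond the scatter is expected in this assay, and no direction is favoured. The estimated change is a number 1 percentage points lower from compound 2 to compound 4 (within the scatter).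

The expected value for compound 4 is 7%, with an estimated range of 0% to 16%.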

Compound 4, percent growth inhibition at one concentration: "not toxic" (no number reported)
Nothing numeric was reported for compound 4, so the estimate cannot be set against anything.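

In this assay, going by these compounds alone, compound 4 gives "not toxic" (no number reported) and compound 2 gives 8%, so no step between them can be read. No evidence bears on this result. The compounds shown leave open how 3-fluorobenzyl and 4-fluorobenzyl compare numerically in this read-out.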